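Series notes: aryl swap on the saturated ring carbon

The source may hold more compounds than are shown below. What is called first, only, known or untested is meant among the compounds shown, and "the series" means these compounds.

Compound 1 `COc1ccc(C2N=C(SCc3ccccc3)NC(C)=C2C(=O)Nc2ccc(F)cc2)cc1OC` is the point of reference. In a functional assay on the whole organism (artery, strain albino) with Rattus norvegicus as the target, with a stated time of 30 min, at a dose of 10 mg/kg by the oral route (on this read-out higher numbers stand for more inhibition at the one dose given (going by the name of the read-out) and lower numbers for less inhibition), compound 1 gives 3.6%, the lowest of the three numbers, though its gaps to the other two fall within the scatter. Compound 2 `COc1ccc(C2N=C(SCc3ccccc3Cl)NC(C)=C2C(=O)Nc2ccc(F)cc2)cc1OC` gives 6.2% and compound 3 `COc1ccc(C2N=C(SCc3ccc(Cl)cc3)NC(C)=C2C(=O)Nc2ccc(F)cc2)cc1OC` gives 5.7% in this assay. Going by the values given here, the steps of a number 2.6 percentage points higher from compound 1 to compound 2 (within the scatter) and a number 2.1 percentage points higher from compound 1 to compound 3 (within the scatter) each put chloro in place of hydrogen on an aromatic carbon of the benzylsulfanyl group, and a number 0.5 percentage points lower from compound 2 to compound 3 (within the scatter) puts 4-chlorophenyl in place of 2-chlorophenyl on the saturated chain carbon bound to a sulfur; all three stay within the scatter, so nothing measured so far moves this assay.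

Compound 4 `CC1=C(C(=O)Nc2ccc(F)cc2)C(c2ccc([N+](=O)[O-])cc2)N=C(SCc2ccccc2)N1` is not yet measured. It differs from compound 1 thus: 4-nitrophenyl in place of 3,4-dimethoxyphenyl on a saturated ring carbon. Among the compounds with values here, no measured step touches this position; the three known steps all concern the benzylsulfanyl group and bear on the new change only by showing how flat this assay has been across the set. The expected step is a number 1.4 percentage points higher from compound 1 to compound 4 (within the scatter), nothing beyond the scatter. Compound 4 is therefore estimated at 5%, with a range from 0% to 15%.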

Compound 4, a percentage reported as inhibition, in the whole organism at one dose (the size of the read-out at that dose, not a potency): 7.2%
Compound 4: middle estimate off by 2.2 percentage points, on the low side; the range from low to high includes it.
By their numbers in this assay, from the lowest: compounds 1, 3, 2 and 4 (each within the scatter of the next).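

In this assay, going by these compounds alone, the first change at this position, 4-nitrophenyl in place of 3,4-dimethoxyphenyl on the saturated ring carbon, gives a number 3.6 percentage points higher from compound 1 to compound 4 (within the scatter). Exchanging the whole aryl group here therefore leaves the read-out as flat as the chloro steps on the benzylsulfanyl group did, and compound 4 at 7.2% still shows only slight inhibition at the one dose given. Nothing available accounts for this flat result or ties it to either aryl group.

Open, on these data alone, is whether any group on this ring carbon, such as an aryl ring bearing an amine or a carboxylic acid, moves the read-out beyond the scatter. Also open, as far as these compounds go, is whether 4-nitrophenyl combined with a chloro on the benzylsulfanyl group does so, and whether replacing the (4-fluorophenyl)carbamoyl group matters more than either.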